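From Bromo to Methoxy in a Growth-Inhibition Series

The source may report more compounds than this note shows. Statements on the series, on what has been measured and on what is new or still open speak of the compounds shown alone.

In a functional assay on MCF7 cells (Homo sapiens) for antiproliferative activity (on this read-out higher numbers stand for weaker inhibition of growth and lower numbers for stronger inhibition of growth), compound 1 `COc1ccc(-c2nc3cc(F)ccc3s2)cc1C` gives 48 nM, while compound 2 `COc1ccc(-c2nc3cc(F)ccc3s2)cc1Br` gives 850 nM, the higher of the two numbers. Compound 3 `COc1ccc(-c2nc3cc(F)ccc3s2)cc1OC` has methoxy in place of bromo on an aromatic carbon, (methoxy in place of bromo on an aromatic carbon). Within the data shown here, one measured step bears on this change, and it is large: an 18-fold higher number from compound 1 to compound 2 (1.25 log units; beyond the scatter), with bromo in place of methyl. Leaving bromo is therefore expected to give a large downward change in this assay, estimated as a 170-fold lower number from compound 2 to compound 3 (2.23 log units; beyond the scatter). For compound 3 the expected value is 5 nM, within an estimated range of 0.05 nM to 150 nM.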

Compound 3, concentration for 50% growth inhibition: < 0.1 nM
Compound 3 ended at the assay's limit (the forecaster's own chance of this, stated with the estimate: 35%); at least 50-fold (1.69 log units) between middle value and limit.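

On this aromatic carbon, ortho to a methoxy group, the choice of group matters far more than the step from methyl to bromo could show: in this assay, methoxy in place of bromo gives an at least 8500-fold lower number from compound 2 to compound 3 (3.92 log units; beyond the scatter), and methoxy in place of methyl gives an at least 480-fold lower number from compound 1 to compound 3 (2.68 log units; beyond the scatter). Methoxy thus stands apart from both bromo and methyl here. Compound 3 sits at a limit of the assay, not at a number, so the full size of both steps stays unknown: the limit of < 0.1 nM in this assay, at which 1 of the 3 values shown sits.

The compounds shown leave open whether this drop belongs to the oxygen of the methoxy group or to the group as a whole. A hydroxyl, an ethoxy or an amine on this carbon would bear on that.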